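Propoxycarbonyl to benzyloxycarbonyl: notes on the series

This account rests on a few compounds, and the source may have more. Where it says the series, first, only, none or still open, it means among the compounds named here.

In a functional assay on A2780 cells (Homo sapiens) for antiproliferative activity, read by MTT assay, with a stated time of 48 h (a higher number here means a weaker inhibitor of growth, a lower number a stronger inhibitor of growth), compound 1 `COc1cc(C2CC(c3ccccc3)=NN2C(=O)OCc2ccccc2)cc(OC)c1OC` is recorded as a limit, > 10000 nM. Compound 2 `CCOC(=O)N1N=C(c2cccc(O)c2)CC1c1cc(OC)c(OC)c(OC)c1` gives 9750 nM. For the measured compounds named here, compound 3 `CCCOC(=O)N1N=C(c2cccc(O)c2)CC1c1cc(OC)c(OC)c(OC)c1` gives 11100 nM, and this value lies within the scatter of the one for compound 2. Going by the values given here, these are the only two true numbers, so compound 3 sits with compound 2 in a single group.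

Compound 4 `COc1cc(C2CC(c3cccc(O)c3)=NN2C(=O)OCc2ccccc2)cc(OC)c1OC` differs from compound 3 by phenyl in place of ethyl on a saturated chain carbon bound to an oxygen next to a carbonyl group, that is, propoxycarbonyl to benzyloxycarbonyl (phenyl in place of ethyl on a saturated chain carbon bound to an oxygen next to a carbonyl group).

Among the compounds with values here, one measured step touches this chain: a 1.1-fold higher number from compound 2 to compound 3 (0.06 log units; within the scatter). That step is a much smaller change, and it shows no effect beyond the scatter. Within the data shown here, compound 1 also carries benzyloxycarbonyl, but it differs elsewhere in the structure, so no measured pair isolates the phenyl. The limit also matters here, (the limit of > 10000 nM in this assay, at which 1 of the 3 values shown sits), and compound 4 may be expected to return one too.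

No shift beyond the scatter is expected in this assay, and the expected step is a 1.2-fold lower number from compound 3 to compound 4 (0.09 log units; within the scatter). The estimate for compound 4 is 9000 nM, with an expected range of 3000 nM to 20000 nM.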

Compound 4, concentration for 50% growth inhibition: > 10000 nM
Compound 4 was reported as a limit; the forecaster's own chance of this, stated with the estimate: 35%; middle value at least 1.1-fold (0.04 log units) from the limit.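

In this assay the change from ethyl to phenyl, on a saturated chain carbon bound to an oxygen next to a carbonyl group, yields no true number: compound 4 is recorded only as a limit, > 10000 nM. For the compounds shown here, the one comparison that can be read is an at least 1.0-fold higher number from compound 2 to compound 4 (0.01 log units; that floor lies within the scatter), so the earlier picture of no shift beyond the scatter along this chain is neither extended to benzyloxycarbonyl nor contradicted by it. The steps to compound 4 from compound 3 and from compound 1 cannot be read, which leaves the phenyl and the hydroxy group on the aromatic carbon without a measured size, and both benzyloxycarbonyl compounds now stand at the same limit: the limit of > 10000 nM in this assay, at which 2 of the 4 values shown sit.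

The compounds shown leave open whether any group at this place can bring a value clearly below those of compound 2 and compound 3, since the only true numbers still come from the two short alkoxycarbonyl compounds. Going by these compounds, how a terminal amine or a carboxylic acid on this chain would read in this assay also remains open.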